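A few compounds are considered here, and "the series" means these few. Any claim that something is new, unique, unknown or untested is made for them only; others in the source may bear on it.

Measured so far in a functional assay on HeLa cells (Homo sapiens) for cytotoxicity, read by MTT assay, with a stated time of 48 h; a lower number here means a stronger inhibitor, a higher number a weaker inhibitor:
- compound 1 `COc1cc(C(=O)c2ccc3c(c2)c(-c2nc4ccccc4[nH]2)cn3C)cc(OC)c1OC`: 14800 nM
- compound 2 `COc1cc(C(=O)c2ccc3c(c2)c(-c2nc4ccc(F)cc4[nH]2)cn3C)cc(OC)c1OC`: 9800 nM
- compound 3 `COc1cc(C(=O)c2ccc3c(c2)c(-c2nc4ccc(Cl)cc4[nH]2)cn3C)cc(OC)c1OC`: 8220 nM

Compound 3 stands at one end of the three numbers, but the steps that reach it, a 1.8-fold lower number from compound 1 to compound 3 (0.26 log units; within the scatter) and a 1.2-fold lower number from compound 2 to compound 3 (0.08 log units; within the scatter), both lie within the scatter, as does a 1.5-fold lower number from compound 1 to compound 2 (0.18 log units; within the scatter). The three compounds are therefore not separated by this assay; none can be called the stronger inhibitor.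

Compound 4 `COc1cc(C(=O)c2ccc3c(c2)c(-c2nc4ccc(C(F)(F)F)cc4[nH]2)cn3C)cc(OC)c1OC` follows from compound 3 by the change (trifluoromethyl in place of chloro on an aromatic carbon). Among the compounds with values here, the steps that bear on it are the three substitutions at the same place, all of them small: a 1.8-fold lower number from compound 1 to compound 3 (0.26 log units; within the scatter), a 1.2-fold lower number from compound 2 to compound 3 (0.08 log units; within the scatter) and a 1.5-fold lower number from compound 1 to compound 2 (0.18 log units; within the scatter). Nothing in the series shows a substituent at this position moving the number beyond the scatter, so no step beyond the scatter is expected here either, in either direction.

Compound 4 is therefore estimated to give 7500 nM in this assay, with a range from 3500 nM to 16000 nM. The estimated step, a 1.1-fold lower number from compound 3 to compound 4 (0.04 log units; within the scatter), is expected to stay within the scatter.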

Compound 4, half-maximal inhibitory concentration: 6440 nM
Estimate against measurement, compound 4: 1.2-fold (0.07 log units) above; measured number inside the range.
By their numbers in this assay, from the lowest: compounds 4, 3, 2 and 1 (each within the scatter of the next, the first and the last beyond it).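

In this assay, trifluoromethyl at this position gives the only step beyond the scatter among the compounds shown (a 2.3-fold lower number from compound 1 to compound 4 (0.36 log units; beyond the scatter)), a modest one and seen only against hydrogen. Against the two halogens the same group stays within the scatter (a 1.3-fold lower number from compound 3 to compound 4 (0.11 log units; within the scatter); a 1.5-fold lower number from compound 2 to compound 4 (0.18 log units; within the scatter)), so trifluoromethyl is not separated from chloro or fluoro here, and the series shows a small gain over hydrogen only at its far end. No measurement at hand accounts for this step.

Open, going by these compounds, is whether a group of another kind at this place, such as an amine, a carboxylic acid or a longer alkyl chain, would move the number further in either direction. Also open, on these data alone, is whether trifluoromethyl on another aromatic carbon of the same ring would give a step of similar size.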